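The source may report more compounds than this note shows. Statements on the series, on what has been measured and on what is new or still open speak of the compounds shown alone.

Measured compounds:
Compound 1, `COCCNS(=O)(=O)CCn1cncc1[N+](=O)[O-]`: 4400000 nM
Compound 2, `COCCNS(=O)(=O)CCn1cnc([N+](=O)[O-])c1`: > 5300000 nM
Compound 3, `O=[N+]([O-])c1cncn1CCS(=O)(=O)NCCO`: 5300000 nM

Of the compounds shown here, three have been tested in a functional assay on HCT-116 cells (Homo sapiens) for cytotoxicity, read by sulforhodamine B assay, with stated times of 4 h and 5 days; a higher number here means a weaker inhibitor, a lower number a stronger inhibitor. Compound 1 gives 4400000 nM and compound 3 gives 5300000 nM. For compound 2 the assay reports only a limit, > 5300000 nM, and not a number.

Compound 1 and compound 3 differ in one place: hydrogen in place of methyl on an oxygen on a saturated carbon. This change produces a 1.2-fold higher number from compound 1 to compound 3 (0.08 log units; within the scatter), so the two compounds cannot be told apart in this assay.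

Compound 2 shares its atoms with compound 1, joined differently; the difference between the two cores is not broken down here. Compound 4, `O=[N+]([O-])c1cn(CCS(=O)(=O)NCCO)cn1`, has not yet been measured. It stands to compound 2 as compound 3 stands to compound 1, the same change at the same place: hydrogen in place of methyl on an oxygen on a saturated carbon.

For the measured compounds named here, because the single measured example of this change gave a 1.2-fold higher number from compound 1 to compound 3 (0.08 log units; within the scatter), the step from compound 2 to compound 4 is expected to be a number no higher from compound 2 to compound 4 (the limit leaves the size open) in this assay. Because one of the three values sits at the limit of > 5300000 nM in this assay, at which 1 of the 3 values shown sits, compound 4 is expected to return a value near or beyond that limit, with an estimate of 5300000 nM and a range from 2500000 nM to 11000000 nM.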

Compound 4, half-maximal inhibitory concentration: 10900000 nM
Beside the measured number, compound 4's estimate is 2.1-fold (0.31 log units) below it, and the stated range covers the measured number.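

In this assay compound 2 carries > 5300000 nM, which is a limit and not a number. No size can therefore be read for the step from compound 2 to compound 4, because of this limit: the limit of > 5300000 nM in this assay, at which 1 of the 4 values shown sits.

The compounds shown leave open whether going from 2-methoxyethyl to 2-hydroxyethyl acts on the core of compound 2 as it does on the core of compound 1.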